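This account rests on a few compounds, and the source may have more. Where it says the series, first, only, none or still open, it means among the compounds named here.

Of the compounds shown here, three built on one shared core have been measured in a physicochemical assay for lipophilicity, read by LC-MS, using the shake flask method, in phosphate buffer, with a stated time of 50 min, at pH 7.4; a higher number here means a more lipophilic compound, a lower number a more polar compound. Compound 1 `Cc1ncsc1-c1ccc(CNC(=O)[C@@H]2C[C@@H](O)CN2C(=O)[C@@H](NC(=O)CCCCCOC(=O)CC(c2ccccc2)c2ccccc2)C(C)(C)C)cc1` gives 1.9. Compound 2 `Cc1ncsc1-c1ccc(CNC(=O)[C@@H]2C[C@@H](O)CN2C(=O)[C@@H](NC(=O)CCCCCOC(=O)C2CCCCC2)C(C)(C)C)cc1` gives 1.1, the second highest of the three numbers, beyond the scatter below compound 1 and beyond the scatter above compound 3. Compound 3 `CCCC(=O)OCCCCCC(=O)N[C@H](C(=O)N1C[C@H](O)C[C@H]1C(=O)NCc1ccc(-c2scnc2C)cc1)C(C)(C)C` gives 0.5. Within the data shown here, the only step between two compounds that differ in a single place is a number 0.60 log units lower from compound 2 to compound 3 (beyond the scatter), a modest fall beyond the scatter.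

Compound 4 `COCC(=O)OCCCCCC(=O)N[C@H](C(=O)N1C[C@H](O)C[C@H]1C(=O)NCc1ccc(-c2scnc2C)cc1)C(C)(C)C` has not yet been measured in this assay. It differs from compound 2 in one place: methoxymethyl in place of cyclohexyl on a carbonyl carbon. The step from compound 2 to compound 3 bears on this change: there too the cyclohexyl on the carbonyl carbon made way for an open chain. Among the measured compounds shown here, in compound 4 the entering group is smaller still and carries one hydrogen-bond acceptor, so a fall at least as large as the one to compound 3, and probably larger, is expected. For compound 4 the step expected is a number 1.20 log units lower from compound 2 to compound 4 (beyond the scatter), downward and beyond the scatter. Compound 4 is therefore estimated at -0.1, with a range from -0.7 to 0.5.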

Compound 4, distribution coefficient: 1.7
Compound 4: the middle estimate sits 1.80 log units below what was measured, outside the stated range (above it).
By their numbers in this assay, from the lowest: compound 3; then compound 2; then compounds 4 and 1 (each within the scatter of the next).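

In this assay, replacing cyclohexyl on this carbonyl carbon with an open-chain group has no single outcome: propyl gave a number 0.60 log units lower from compound 2 to compound 3 (beyond the scatter), whereas methoxymethyl gives a number 0.60 log units higher from compound 2 to compound 4 (beyond the scatter), the opposite direction, even though methoxymethyl has fewer heavy atoms than the cyclohexyl it replaces. The comparison of the two open-chain groups is sharper still, since methoxy in place of ethyl on the saturated chain carbon bound to the carbonyl carbon gives a number 1.20 log units higher from compound 3 to compound 4 (beyond the scatter), so the result depends on more than whether a ring leaves. Compounds 1, 2 and 3 alone suggested that the number falls as the group on this carbonyl carbon gets smaller, and compound 4 goes against that pattern, while the available data offer no explanation for the reversal.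

The compounds shown rest this finding on a single oxygen-bearing group, so it remains open whether ethoxymethyl, hydroxymethyl or a longer methoxyethyl chain would behave like methoxymethyl. From the compounds shown here alone, it is equally open where an amine such as dimethylaminomethyl or a carboxylic acid would fall at this same place.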